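Swapping a Benzyl Halogen While Toxicity Stays Unseen

A few compounds are considered here, and "the series" means these few. Any claim that something is new, unique, unknown or untested is made for them only; others in the source may bear on it.

Compound 2 `Fc1ccccc1Cn1ccc2nc(-c3ccccc3)nc-2c1` was examined in an ADME assay on MDBK cells (Bos taurus) for cytotoxicity; on this read-out higher numbers stand for lower toxicity in this test and lower numbers for higher toxicity in this test. In this assay compound 2 gives > 100000 nM, which is a limit of the assay rather than a measured number. Compound 1 `Fc1cccc(F)c1-c1nc2ccn(Cc3ccccc3)cc-2n1` sits at the same kind of limit, giving > 100000 nM in this assay. Compound 3 `FC(F)(F)c1ccccc1Cn1ccc2nc(-c3ccccc3)nc-2c1` likewise gives > 100000 nM in this assay, again only a limit. Among the measured compounds shown here, because of the limit of > 100000 nM in this assay, at which 3 of the 3 values shown sit, the single measured step, a step that the two limits leave unreadable from compound 2 to compound 3, cannot be sized. Compound 4 `Ic1ccc(Cn2ccc3nc(-c4ccccc4)nc-3c2)cc1` differs from compound 2 by 4-iodophenyl in place of 2-fluorophenyl on a saturated chain carbon bound to an aromatic nitrogen. For the measured compounds named here, no measured step touches that change, and no compound here yields a real number, so no shift beyond scatter is expected. Compound 4 is estimated at 100000 nM, within 30000 nM to 300000 nM, an expected step of a number no higher from compound 2 to compound 4 (the limit leaves the size open).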

Compound 4, half-maximal cytotoxic concentration: 22000 nM
Compound 4: middle estimate off by 4.5-fold (0.66 log units), on the high side; measured number outside the range, below it.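

Compound 4 is the only compound shown that gives a real number in this assay, so the group on the saturated chain carbon bound to an aromatic nitrogen can change toxicity in this test. Putting 4-iodophenyl in place of 2-fluorophenyl gives an at least 4.5-fold lower number from compound 2 to compound 4 (0.65 log units; beyond the scatter), which points to higher toxicity in this test. That size is only a minimum, since compound 2 stands at a limit, and the other values give little to compare it with: the limit of > 100000 nM in this assay, at which 3 of the 4 values shown sit.

Going by these compounds, whether the drop follows the iodine itself or its place on the ring remains open. So does the result of an amine or a carboxylic acid on that phenyl ring.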